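A few compounds are considered here, and "the series" means these few. Any claim that something is new, unique, unknown or untested is made for them only; others in the source may bear on it.

In a functional assay on HeLa cells (Homo sapiens) for cytotoxicity, read by MTT assay, with a stated time of 48 h (on this read-out higher numbers stand for weaker inhibition and lower numbers for stronger inhibition), compound 2 `COc1ccccc1C(c1c(-c2ccccc2)c[n+]([O-])c2c(C)noc12)c1c(-c2ccccc2)c[n+]([O-])c2c(C)noc12` gives 65.5 ug/mL and compound 1 `Cc1ccccc1C(c1c(-c2ccccc2)c[n+]([O-])c2c(C)noc12)c1c(-c2ccccc2)c[n+]([O-])c2c(C)noc12` gives 62.4 ug/mL, so the two cannot be told apart. Within the data shown here, the only measured step, a 1.0-fold higher number from compound 1 to compound 2 (0.02 log units; within the scatter), swaps methyl for methoxy on an aromatic carbon. Compound 3 `Cc1noc2c(C(c3ccc(Cl)cc3)c3c(-c4ccccc4)c[n+]([O-])c4c(C)noc34)c(-c3ccccc3)c[n+]([O-])c12` differs from compound 2 as follows: 4-chlorophenyl in place of 2-methoxyphenyl on a saturated chain carbon bound to two aromatic carbons. That is 4-chlorophenyl in place of 2-methoxyphenyl on a saturated chain carbon bound to two aromatic carbons. Among the measured compounds shown here, no measured step covers this swap, so the guide is weak, and no shift beyond the scatter is expected in this assay. The expected change is a 1.2-fold lower number from compound 2 to compound 3 (0.08 log units; within the scatter). For compound 3 the estimated value is 55 ug/mL, within a range of 22 ug/mL to 120 ug/mL.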

Compound 3, half-maximal inhibitory concentration: 70.7 ug/mL
Beside the measured number, compound 3's estimate is 1.3-fold (0.11 log units) below it; the measured number falls inside the stated range.
By their numbers in this assay, from the lowest: compounds 1, 2 and 3 (each within the scatter of the next).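

Putting 4-chlorophenyl on the saturated chain carbon in place of 2-methoxyphenyl gives a 1.1-fold higher number from compound 2 to compound 3 (0.03 log units; within the scatter) in this assay, and putting it there in place of 2-methylphenyl gives a 1.1-fold higher number from compound 1 to compound 3 (0.05 log units; within the scatter) in the same assay. This position has therefore now carried three differently substituted phenyl rings with no shift beyond the scatter, even with chlorine replacing the earlier groups. No available evidence bears on why these numbers stay so close. Still open, on these data alone, is whether a phenyl ring bearing an amine or a carboxylic acid, or a simple alkyl chain in place of the ring, would move the number.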